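The source may hold more compounds than are shown below. What is called first, only, known or untested is meant among the compounds shown, and "the series" means these compounds.

Compound 1 `FC(F)(F)c1ccc(-c2cc(-c3ccccc3-c3ccccc3)n[nH]2)cc1` sets the starting point: in a functional assay on OVCAR cells (Homo sapiens) for inhibition, read by MTT assay, with a stated time of 48 h (a lower number here means a stronger inhibitor of growth, a higher number a weaker inhibitor of growth), compound 1 gives 2750 nM. Compound 2 `Oc1ccc(-c2cc(-c3ccccc3-c3ccccc3)n[nH]2)cc1` keeps the shared core and carries a hydroxy where compound 1 carries a trifluoromethyl; in this assay compound 2 gives 6200 nM. Among the measured compounds shown here, the single step between them, a 2.3-fold higher number from compound 1 to compound 2 (0.35 log units; beyond the scatter), is modest but lies beyond the scatter. For the measured compounds named here, of the two numbers so far, compound 2 stands at the highest, with compound 1 as its only neighbour at the lower number.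

Compound 3 `O=[N+]([O-])c1ccc(-c2cc(-c3ccccc3-c3ccccc3)n[nH]2)cc1` is the next variation at the same position on the shared core. The change from compound 2 is nitro in place of hydroxy on an aromatic carbon. Going by the values given here, only one measured step bears on it, a 2.3-fold higher number from compound 1 to compound 2 (0.35 log units; beyond the scatter), which shows that putting the hydroxy on this aromatic carbon raised the number relative to the trifluoromethyl. Removing the hydroxy again and putting a nitro in its place is therefore expected to move the number back down by a modest amount, a 1.8-fold lower number from compound 2 to compound 3 (0.25 log units; within the scatter), toward the value of compound 1. For compound 3 the estimate in this assay is 3500 nM, with a likely range from 1500 nM to 8000 nM.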

Compound 3, concentration for 50% growth inhibition: 3400 nM
For compound 3 the middle estimate is 1.0-fold (0.01 log units) above the measured one; measured number inside the range.
By their numbers in this assay, from the lowest: compounds 1, 3 and 2 (each within the scatter of the next, the first and the last beyond it).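

In this assay, the nitro on this aromatic carbon, para to a large group, cannot be separated from either group tested there before: the swap for trifluoromethyl gives a 1.2-fold higher number from compound 1 to compound 3 (0.09 log units; within the scatter), and the swap for hydroxy gives a 1.8-fold lower number from compound 2 to compound 3 (0.26 log units; within the scatter). Among the compounds shown here, the third group therefore adds no new level of growth inhibition at this position, and the only step beyond the scatter remains a 2.3-fold higher number from compound 1 to compound 2 (0.35 log units; beyond the scatter), so a small gap now joins compound 1 and compound 2 through a nitro compound that is distinguishable from neither. No measurement is available here that would explain these numbers, whether for the nitro or for the other two groups.

The three compounds leave open whether an amine, a carboxylic acid, a chlorine or a longer chain such as a methoxyethyl on this aromatic carbon would move the number clearly away from this narrow set of values. They also leave open whether any group at this position could matter more than the modest step seen so far, since every change shown falls on this one carbon of the shared core.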